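Fluoro in place of chloro on compound 3

This account rests on a few compounds, and the source may have more. Where it says the series, first, only, none or still open, it means among the compounds named here.

Compound 1 `COc1ccc(/C=C2\CN(Cc3cn(Cc4cccc(Cl)c4)nn3)C/C(=C\c3ccc(OC)cc3)C2=O)cc1` and compound 2 `COc1ccc(/C=C2\CN(Cc3cn(Cc4ccc(F)cc4)nn3)C/C(=C\c3ccc(OC)cc3)C2=O)cc1` share their core with compound 3 `COc1ccc(/C=C2\CN(Cc3cn(Cc4ccccc4Cl)nn3)C/C(=C\c3ccc(OC)cc3)C2=O)cc1` and compound 4 `COc1ccc(/C=C2\CN(Cc3cn(Cc4ccccc4F)nn3)C/C(=C\c3ccc(OC)cc3)C2=O)cc1`, and the four differ only in the halogen substitution of one phenyl ring. In a functional assay on MDA-MB-231 cells (Homo sapiens) for cytotoxicity, read by MTT assay, with a stated time of 24 h (a higher number here means a weaker inhibitor, a lower number a stronger inhibitor), compound 1 gives 98000 nM and compound 2 gives 70700 nM. Compound 3 has no exact number, only a limit of the assay: > 100000 nM.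

The change to compound 4 is fluoro in place of chloro on an aromatic carbon, ortho to a large group, so 2-chlorophenyl becomes 2-fluorophenyl. Two measured steps reach compound 3, an at least 1.0-fold higher number from compound 1 to compound 3 (0.00 log units; that floor lies within the scatter) and an at least 1.4-fold higher number from compound 2 to compound 3 (0.15 log units; that floor lies within the scatter). From the compounds shown here alone, both are only floors, so the true distance of compound 3 from the others stays open. Within the data shown here, no measured step swaps chloro for fluoro at a single place. The nearest guide is the step of a 1.4-fold lower number from compound 1 to compound 2 (0.14 log units; within the scatter), which also exchanges one halogenated phenyl group for another and stays within the scatter.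

In this assay no step beyond the scatter is therefore expected, and the estimated step is an at least 1.1-fold lower number from compound 3 to compound 4 (0.04 log units; that floor lies within the scatter). For compound 4 the expected value is 90000 nM, with an estimated range from 50000 nM to 150000 nM.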

Compound 4, half-maximal inhibitory concentration: 67200 nM
Compound 4: middle estimate off by 1.3-fold (0.13 log units), on the high side; low and high end bracket the measured number.
By their numbers in this assay, from the lowest: compounds 4, 2 and 1 (each within the scatter of the next). At a limit, above all of these: compound 3.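

In this assay, the change of chloro to fluoro, ortho to a large group, yields the only exact number among the compounds shown for a halogen at this place, but the step, an at least 1.4-fold lower number from compound 3 to compound 4 (0.17 log units; that floor lies within the scatter), is just a floor, and its true size stays unknown because compound 3 sits at a limit of the assay: the limit of > 100000 nM in this assay, at which 1 of the 4 values shown sits. With an exact value at this place, the fluoro group can now be compared with the 4-fluorophenyl compound, a 1.1-fold lower number from compound 2 to compound 4 (0.02 log units; within the scatter), and with the 3-chlorophenyl compound, a 1.5-fold lower number from compound 1 to compound 4 (0.16 log units; within the scatter), and both steps lie within the scatter. Among compound 1, compound 2 and compound 4, neither the kind of halogen nor its place on the ring therefore gives a readable difference, while compound 3 cannot be placed relative to them.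

From the compounds shown here alone, whether 2-chlorophenyl truly differs from 2-fluorophenyl remains open, as the limit on compound 3 gives no upper end to that step. Also open, going by these compounds, is whether a group of another kind at this place, such as an amine, a methoxy group or a carboxylic acid, would move the number beyond the scatter.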